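From Fluoro to Trifluoromethoxy on the Same Aromatic Ring

The compounds below may be only part of what the source reports. "The series", "measured", "known", "first", "only" and "open" are said of these compounds alone.

Measured compounds:
Compound 1, `O=C(O)c1csc([C@H]2CC[C@@H]3[C@@H](COc4ccc(C(F)(F)F)cc4)[C@H](O)C[C@@H]3O2)n1`, gives 13 nM in a functional assay on CHO cells for agonist activity at prostaglandin E2 receptor EP2 subtype (Homo sapiens), read by HTRF and cAMP accumulation, with a stated time of 30 min; a lower number here means that less compound is needed, a higher number that more compound is needed for the effect.
Compound 2, `O=C(O)c1csc([C@H]2CC[C@@H]3[C@@H](COc4cccc(F)c4)[C@H](O)C[C@@H]3O2)n1`, gives 5.4 nM in this assay.

Among the measured compounds shown here, compound 2 stands at the lowest of the two numbers in this assay, with compound 1 as its only neighbour; the one step between them, a 2.4-fold lower number from compound 1 to compound 2 (0.38 log units; beyond the scatter), is modest but beyond the scatter.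

Compound 3, `O=C(O)c1csc([C@H]2CC[C@@H]3[C@@H](COc4cccc(OC(F)(F)F)c4)[C@H](O)C[C@@H]3O2)n1`, has not yet been measured. It differs from compound 2 in one place: trifluoromethoxy in place of fluoro on an aromatic carbon. For the measured compounds named here, no measured step matches this change. Going by the values given here, the single step available, a 2.4-fold lower number from compound 1 to compound 2 (0.38 log units; beyond the scatter), alters both the group and its position on the ring at once, so it speaks only indirectly to a group swap at a fixed position. Among the compounds with values here, with no direct precedent, the expectation is for no step beyond the scatter in this assay, in either direction, with the range widened to cover a modest move.

Compound 3 is therefore expected to give about 7 nM, within a range from 2.5 nM to 20 nM. This estimate means a step of a 1.3-fold higher number from compound 2 to compound 3 (0.11 log units; within the scatter), expected to lie within the scatter.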

Compound 3, half-maximal effective concentration: 0.9 nM
Compound 3: middle estimate off by 7.8-fold (0.89 log units), on the high side; the measured number lies below the stated range.
By their numbers in this assay, from the lowest: compound 3; then compound 2; then compound 1.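

In this assay, trifluoromethoxy in place of fluoro on an aromatic carbon, meta to a large group, gives a 6.0-fold lower number from compound 2 to compound 3 (0.78 log units; beyond the scatter), so the number at this position clearly depends on the group it carries. Unlike the earlier 2.4-fold lower number from compound 1 to compound 2 (0.38 log units; beyond the scatter), which altered the group and its place on the ring together, this step keeps the place fixed and so reads the group swap alone; it also shows that going from one heavy atom to five, with one hydrogen-bond acceptor added, does not cost activity here. Nothing measured in this set bears on why the number falls.

Going by these compounds, whether methoxy or trifluoromethyl on the same aromatic carbon would reach a number like that of compound 3 remains open, so the part played by the oxygen cannot be separated from that of the fluorines. Also open, on these data alone, is whether trifluoromethoxy would give a similar step at the ring position that carries trifluoromethyl in compound 1, or whether the gain belongs to the position named here alone.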